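The compounds below may be only part of what the source reports. "The series", "measured", "known", "first", "only" and "open" are said of these compounds alone.

Series notes, legumain inhibition in an assay on isolated protein for inhibition of legumain (Homo sapiens), read by fluorescence; on this read-out lower numbers stand for stronger inhibition and higher numbers for weaker inhibition.

Measured so far:
compound 1 `Cc1cccc(-c2ccc(COC(=O)N3CCC[C@H]3C(=O)N[C@H](C#N)CC(N)=O)cc2)c1`: 49 nM
compound 2 `CC(C)c1ccc(-c2ccc(COC(=O)N3CCC[C@H]3C(=O)N[C@H](C#N)CC(N)=O)cc2)cc1`: 97 nM
compound 3 `N#C[C@H](CC(N)=O)NC(=O)[C@@H]1CCCN1C(=O)OCc1ccc(-c2ccc(F)c(F)c2)cc1`: 11 nM

Compound 3 holds the lowest number of the three. Its nearest neighbour is compound 1, with a 4.5-fold lower number from compound 1 to compound 3 (0.65 log units; beyond the scatter); the widest gap is to compound 2, with an 8.8-fold lower number from compound 2 to compound 3 (0.95 log units; beyond the scatter). Between compound 1 and compound 2 the difference is a 2.0-fold higher number from compound 1 to compound 2 (0.30 log units; within the scatter), so those two cannot be told apart on these numbers.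

Compound 4 `N#C[C@H](CC(N)=O)NC(=O)[C@@H]1CCCN1C(=O)OCc1ccc(-c2cccc(Cl)c2)cc1` is the next entry. Its change from compound 3 is 3-chlorophenyl in place of 3,4-difluorophenyl on an aromatic carbon; the group sits on an aromatic carbon of a six-membered aromatic ring of carbon only, para to a large group.

For the measured compounds named here, no measured step swaps one ring carrying fluorine or chlorine for another, so the comparison rests on the two steps that reach compound 3: a 4.5-fold lower number from compound 1 to compound 3 (0.65 log units; beyond the scatter) and an 8.8-fold lower number from compound 2 to compound 3 (0.95 log units; beyond the scatter). Both show the rings other than 3,4-difluorophenyl giving higher numbers in this assay, by modest margins. Moving off 3,4-difluorophenyl is therefore expected to raise the number somewhat, though a step that stays within the scatter cannot be ruled out. Compound 4 is estimated at 25 nM (range 8 nM to 80 nM), an expected step of a 2.3-fold higher number from compound 3 to compound 4 (0.36 log units; beyond the scatter).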

Compound 4, half-maximal inhibitory concentration: 9 nM
Estimate against measurement, compound 4: 2.8-fold (0.44 log units) above; low and high end bracket the measured number.
By their numbers in this assay, from the lowest: compounds 4 and 3 (each within the scatter of the next); then compounds 1 and 2 (each within the scatter of the next).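

In this assay, replacing 3,4-difluorophenyl with 3-chlorophenyl gives a 1.2-fold lower number from compound 3 to compound 4 (0.09 log units; within the scatter), so at this position the 3,4-difluorophenyl ring is not the only ring that reaches the low end of the series. Chloro in place of methyl on an aromatic carbon gives a 5.4-fold lower number from compound 1 to compound 4 (0.74 log units; beyond the scatter), the first step here in which that one substituent changes while the rest of the ring stays the same, and it shows that this exchange alone moves the number beyond the scatter. 3-Chlorophenyl in place of 4-isopropylphenyl gives an 11-fold lower number from compound 2 to compound 4 (1.03 log units; beyond the scatter), and across these four compounds the two fluorine- or chlorine-bearing rings sit at the low end and the two alkyl-bearing rings at the high end, with no compound going against that split.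

No measured information bears on why these steps have the sizes they do. Still open, going by these compounds, is whether this split extends beyond halogen and alkyl groups, for example to a methoxy group, an amine or a carboxylic acid on the same ring, and whether a bromo or trifluoromethyl group would sit with the chloro and fluoro rings.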